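The source may report more compounds than this note shows. Statements on the series, on what has been measured and on what is new or still open speak of the compounds shown alone.

Cytotoxicity here was measured with a functional assay on B16-F10 cells (Mus musculus) for cytotoxicity, read by MTT assay, with a stated time of 48 h; on this read-out higher numbers stand for weaker inhibition and lower numbers for stronger inhibition. Compound 1, `Fc1ccc2nc(NC(=S)Nc3ccc(Cl)cc3)sc2c1`, carries a fluoro on its fused core and a chloro on the outer phenyl ring; in this assay compound 1 gives 48100 nM. Compound 2, `S=C(Nc1ccccc1)Nc1nc2ccccc2s1`, lacks both of these halogens. In this assay compound 2 reaches only a limit, recorded as > 50000 nM, so no exact number is known for it; this is the limit of > 50000 nM in this assay, at which 1 of the 2 values shown sits, and it places compound 2 at the weak end of what the assay can report.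

Compound 3, `Fc1ccc2nc(NC(=S)Nc3ccccc3)sc2c1`, differs from compound 2 in a single place: fluoro in place of hydrogen on an aromatic carbon. Compound 1 carries the same fluoro at the same place, together with a chloro, and its value in this assay sits close to that limit. Because of 48100 nM for compound 1, the step from compound 2 to compound 3 is expected to be a number no higher from compound 2 to compound 3 (the limit leaves the size open), that is, no change beyond the usual scatter. Compound 3 is therefore estimated at 50000 nM, with a likely range from 25000 nM to 100000 nM.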

Compound 3, half-maximal inhibitory concentration: > 50000 nM
Compound 3: only a limit was reported (the forecaster's own chance of this, stated with the estimate: 55%); the middle value sits exactly at the limit.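

In this assay compound 3 ends at a limit rather than a number, just as compound 2 does, so the change from hydrogen to fluoro at this place on the fused system has no readable size: the limit of > 50000 nM in this assay, at which 2 of the 3 values shown sit.

The new information is that fluoro alone, with no chloro on the outer phenyl ring, does not bring a compound to an exact value in this assay. Hydrogen in place of chloro gives an at least 1.0-fold higher number from compound 1 to compound 3 (0.01 log units; that floor lies within the scatter), so the chloro cannot be credited with any real gain, even though compound 1 is the only one of the three with an exact value.

On these data alone, it remains open whether a real difference between compound 1 and compound 3 lies hidden beyond the limit, and what chloro would do on the outer phenyl ring without the fluoro. Also open, as far as these compounds go, is how another group at the fluoro's place, such as an amine or a methoxy group, would read in this assay.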